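Methoxy on the pendant phenyl of compound 1

A few compounds are considered here, and "the series" means these few. Any claim that something is new, unique, unknown or untested is made for them only; others in the source may bear on it.

Compound 1 `O=c1cc(-c2ccccc2)oc2ccc(OCCCCCCN3CCC(O)CC3)cc12` carries a 4-hydroxypiperidin-1-yl on the chain. In an assay on isolated protein (Cavia porcellus) with Sigma non-opioid intracellular receptor 1 (Homo sapiens) as the target, read by radioligand binding (a lower number here means a stronger inhibitor, a higher number a weaker inhibitor), compound 1 gives 100 nM. Compound 2 `CN(CCCCCCOc1ccc2oc(-c3ccccc3)cc(=O)c2c1)Cc1ccccc1` gives 52 nM in this assay, and compound 3 `CCOC(=O)C1CCN(CCCCCCOc2ccc3oc(-c4ccccc4)cc(=O)c3c2)CC1` gives 164 nM. Among the measured compounds shown here, the steps from compound 1 are a 1.9-fold lower number from compound 1 to compound 2 (0.28 log units; within the scatter) and a 1.6-fold higher number from compound 1 to compound 3 (0.21 log units; within the scatter); the only step past the scatter is a 3.2-fold higher number from compound 2 to compound 3 (0.50 log units; beyond the scatter). Compound 1 thus sits among numbers that do not separate from its own.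

Compound 4 `COc1cccc(-c2cc(=O)c3cc(OCCCCCCN4CCC(O)CC4)ccc3o2)c1` differs from compound 1 by methoxy in place of hydrogen on an aromatic carbon, on the aromatic carbon meta to a large group; cut one bond further out, the change reads phenyl to 3-methoxyphenyl.

None of the measured steps touches this ring: all three alter the amine at the chain end, and their sizes, as given above, say nothing about a methoxy here. For the measured compounds named here, there is no measured step that bears on the change, so no direction can be read from the series.

The expectation for compound 4 in this assay is therefore a step of no change at the digits printed from compound 1 to compound 4 (within the scatter), none beyond the scatter, with an estimate of 100 nM and a range from 35 nM to 300 nM.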

Compound 4, half-maximal inhibitory concentration: 76 nM
The estimate for compound 4 lay 1.3-fold (0.12 log units) above the measured number, within the range that was stated.
By their numbers in this assay, from the lowest: compounds 2, 4, 1 and 3 (each within the scatter of the next, the first and the last beyond it).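

In this assay, phenyl to 3-methoxyphenyl gives a 1.3-fold lower number from compound 1 to compound 4 (0.12 log units; within the scatter), so this methoxy, on the aromatic carbon meta to a large group, does not separate compound 4 from compound 1. Among the compounds shown here, this is the first reading on this ring, as the earlier steps all altered the amine at the chain end, and it shows that the ring can carry a methoxy here with no change beyond the scatter. No measurement on hand accounts for this outcome.

The compounds shown leave open whether a hydroxy, a chloro or a larger ethoxy on the same carbon would separate from compound 1. Also open, as far as these compounds go, is whether the methoxy gives a similar step when paired with the benzyl(methyl)amino of compound 2 or the 4-(ethoxycarbonyl)piperidin-1-yl of compound 3.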